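This account rests on a few compounds, and the source may have more. Where it says the series, first, only, none or still open, it means among the compounds named here.

Measured compounds:
compound 1, `c1ccc(-n2cc3cnc(-c4ccsc4)cc3n2)cc1`: 8300 nM
compound 2, `Cc1nccc2nn(-c3ccccc3)cc12`: > 100000 nM
compound 3, `Cn1cc2cnc(-c3ccccc3)cc2n1`: > 100000 nM

In a functional assay on K562 cells (Homo sapiens) for inhibition, read by fluorescence, with a stated time of 72 h (a lower number here means a stronger inhibitor of growth, a higher number a weaker inhibitor of growth), compound 2 gives only a limit, > 100000 nM. Compound 3 likewise gives only a limit in this assay, > 100000 nM. Compound 2 therefore stands at the limit of > 100000 nM in this assay, at which 2 of the 3 values shown sit, together with compound 3, so no number is known for it. Going by the values given here, compound 1, which carries a phenyl on the ring nitrogen together with a thiophene ring, is the only compound with a number, and in this assay compound 1 gives 8300 nM.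

Compound 4, `Cc1nc(-c2ccccc2)cc2nn(-c3ccccc3)cc12`, differs from compound 2 in one place: phenyl in place of hydrogen on an aromatic carbon. Among the compounds with values here, no measured pair shows this change, so the size of the step is not known from data. Compound 1 suggests that an extra aromatic ring can bring the value into the measurable range, and on that basis the step of an at least 6.6-fold lower number from compound 2 to compound 4 (0.82 log units; beyond the scatter) is expected to be toward stronger inhibition, beyond the scatter. Compound 4 is accordingly estimated at 15000 nM, with a range from 4000 nM to 80000 nM.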

Compound 4, concentration for 50% growth inhibition: 6300 nM
Estimate against measurement, compound 4: 2.4-fold (0.38 log units) above, within the range that was stated.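

In this assay, going by these compounds alone, phenyl in place of hydrogen on an aromatic carbon, next to the ring nitrogen, gives the first step that can be read between two compounds differing in one place: an at least 15-fold lower number from compound 2 to compound 4 (1.20 log units; beyond the scatter). It shows that this position of the six-membered aromatic ring with 1 nitrogen accepts a phenyl and that the change alone moves the value from a limit into the measurable range, well beyond the scatter. The full size of the step stays unknown because compound 2 is known only as a limit: the limit of > 100000 nM in this assay, at which 2 of the 4 values shown sit.

The compounds shown leave open how a cyclohexyl ring, an amine or a carboxylic acid would compare with phenyl at this position. They also do not tell whether the methyl group on the same ring contributes to the gain.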